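Replacing the aryl group on the core: cyclohexyl analogue

The source may report more compounds than this note shows. Statements on the series, on what has been measured and on what is new or still open speak of the compounds shown alone.

Measured so far:
compound 1 `Cc1cc(C(=O)O)ccc1C(C)N1CCC[C@H](O[C@H](CO)c2cc(Cl)cc(Cl)c2)[C@@H]1c1ccccc1` gives 18000 nM
compound 2 `Cc1cc(C(=O)O)ccc1CN1CCC[C@H](O[C@H](CO)c2cc(Cl)cc(Cl)c2)[C@@H]1c1ccc(F)cc1` gives 18000 nM
compound 3 `Cc1cc(C(=O)O)ccc1CN1C(C)CC[C@H](O[C@H](CO)c2cc(Cl)cc(Cl)c2)[C@@H]1c1ccccc1` gives 36000 nM

All three numbers come from an assay on isolated protein for activation of cGMP-dependent protein kinase 1 (Homo sapiens), read by ADP-Glo, with stated times of 30 min and 2 h, in the presence of a further agent that is not named here; a higher number here means that more compound is needed for the effect, a lower number that less compound is needed. Compound 2 and compound 1 are level at the digits shown, and together they give the lowest numbers of the three. Compound 3 gives a higher number, but its distance from compound 2 stays within the usual scatter of repeated measurements, so no order among the three compounds can be read from these values.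

The next compound, compound 4 `Cc1cc(C(=O)O)ccc1CN1CCC[C@H](O[C@H](CO)c2cc(Cl)cc(Cl)c2)[C@@H]1C1CCCCC1`, has not been measured. It differs from compound 2 in one place: cyclohexyl in place of 4-fluorophenyl on a saturated ring carbon

Among the compounds with values here, no pair of measured compounds differs in exactly one place, so no step of this kind is available to lean on. The three numbers obtained so far all lie close together despite changes around the core, which gives no ground for expecting a large move in either direction. The estimate for compound 4 in this assay is therefore 25000 nM, with a range from 8000 nM to 80000 nM, and the step it implies, a 1.4-fold higher number from compound 2 to compound 4 (0.14 log units; within the scatter), is expected to stay within the scatter, with a slight lean towards a higher number.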

Compound 4, half-maximal effective concentration: 65000 nM
The estimate for compound 4 lay 2.6-fold (0.41 log units) below the measured number; the measured number falls inside the stated range.
By their numbers in this assay, from the lowest: compounds 1, 2, 3 and 4 (each within the scatter of the next, the first and the last beyond it).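

In this assay the exchange of 4-fluorophenyl for cyclohexyl on the saturated ring carbon gives a 3.6-fold higher number from compound 2 to compound 4 (0.56 log units; beyond the scatter) and, though modest, this step lies beyond the scatter. Within the data shown here, it is the first change confined to one place, and it shows that this position responds to the group it carries: with all else held constant, a six-membered aromatic ring of carbon only gives a lower number than a six-membered non-aromatic ring of carbon only, a comparison the earlier compounds, which differ in more than one place, could not provide. Nothing available accounts for the step, so it stands as an observation on these two compounds alone.

The pair leaves open whether the difference follows the aromatic ring or the fluorine, as a single pair cannot separate the two. Going by these compounds, how this position would respond to a pyridyl ring, a smaller cyclopentyl ring or an amine-bearing piperidinyl ring also remains open, as does whether any group here could bring the number below that of compound 2 18000 nM.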